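A few compounds are considered here, and "the series" means these few. Any claim that something is new, unique, unknown or untested is made for them only; others in the source may bear on it.

Measured compounds, with their inhibition read-outs in an assay on isolated protein for inhibition of 3',5'-cyclic-AMP phosphodiesterase 4A (Cavia porcellus), read by cAMP accumulation, tested at 100 uM; on this read-out lower numbers stand for a weaker effect and higher numbers for a stronger effect at the one concentration tested:

Compound 1, `CC(=O)c1cc(C(=O)c2ccccc2)c(=O)[nH]c1C`: 8.9%
Compound 2, `O=C1CCCc2[nH]c(=O)c(C(=O)c3ccccc3)cc21`: 6%
Compound 3, `CC(=O)c1cc(C(=O)C(C)(C)C)c(=O)[nH]c1C`: 8.23%

All three numbers in this assay sit low and close together. Compound 2 carries a core that differs from that of compound 1 by more than one feature, and the difference between the two cores is not broken down here; the two values show only that both lie within the scatter of each other.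

Compound 1 and compound 3 share a core and differ by tert-butyl in place of phenyl on a carbonyl carbon. This change gives a number 0.7 percentage points lower from compound 1 to compound 3 (within the scatter), so within the scatter of this assay no shift is attached to it in this pair.

Compound 4, `CC(C)(C)C(=O)c1cc2c([nH]c1=O)CCCC2=O`, is not yet measured. It relates to compound 2 as compound 3 relates to compound 1: the difference is tert-butyl in place of phenyl on a carbonyl carbon, the same change at the same place, a carbonyl carbon whose other neighbour is an aromatic carbon. The series holds this change twice in all, once measured and once pending.

Because the measured instance of the change gave a number 0.7 percentage points lower from compound 1 to compound 3 (within the scatter), the step to compound 4 is expected to be small as well, estimated as a number 0.5 percentage points lower from compound 2 to compound 4 (within the scatter). Compound 4 is therefore expected to read about 5.5% in this assay, with a likely range from 0% to 14%, all of it within the scatter of compound 2's value. Any larger shift would go against the only comparable step in the set.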

Compound 4, a percentage reported as inhibition, at one concentration (the size of the read-out at that concentration, not a potency): 6.6%
Compound 4: middle estimate off by 1.1 percentage points, on the low side; measured number inside the range.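

In this assay, tert-butyl in place of phenyl on a carbonyl carbon gives a number 0.6 percentage points higher from compound 2 to compound 4 (within the scatter) on the second core, and the change carries from one core to the other with no difference that can be read: the same change on two cores in this assay, a number 0.7 percentage points lower (within the scatter) from compound 1 to compound 3 and a number 0.6 percentage points higher (within the scatter) from compound 2 to compound 4, 1.3 percentage points apart, within the scatter of two such steps. On both cores the swap leaves the read-out within the scatter, so the two pairs agree only in showing no measurable shift at the one concentration tested. They do not show that the two groups are interchangeable in general: all four numbers sit low, a single-concentration read-out gives no potency, and a small true effect of the change, or a dependence on the core, could lie hidden in the scatter.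

The compounds shown place only phenyl and tert-butyl on this carbonyl carbon, both groups of carbon alone with no hydrogen-bond donors or acceptors, so it stays open how an amine, a carboxylic acid or a longer chain would read at that place. From the compounds shown here alone, it also stays open whether the same swap would hold on a core that gives a read-out clear of the scatter.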